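Methyl to ethyl on the core of compound 1

The compounds below may be only part of what the source reports. "The series", "measured", "known", "first", "only" and "open" are said of these compounds alone.

Compound 1 `COC(=O)c1c(C)[n+]([O-])c2cc(F)c(F)cc2[n+]1[O-]` gives the lowest number of the two reported in an ADME assay on Vero cells (Chlorocebus sabaeus) for cytotoxicity (a lower number here means a stronger inhibitor, a higher number a weaker inhibitor), 1.48 ug/mL; compound 3 `CCc1c(C(=O)OC)[n+]([O-])c2cc(OC)ccc2[n+]1[O-]` stands nearest, at 40 ug/mL. Compound 2 `CCc1c(C(=O)OC)[n+]([O-])c2cc(C)ccc2[n+]1[O-]` reaches only a limit, > 62.5 ug/mL (the limit of > 62.5 ug/mL in this assay, at which 1 of the 3 values shown sits). Within the data shown here, the only measured step, an at least 1.5-fold lower number from compound 2 to compound 3 (0.19 log units; that floor lies within the scatter), changes a ring substituent and does not touch the chain. Compound 4 `CCc1c(C(=O)OC)[n+]([O-])c2cc(F)c(F)cc2[n+]1[O-]` differs from compound 1 by methyl in place of hydrogen on a saturated chain carbon bound to an aromatic carbon. Among the measured compounds shown here, compounds 2 and 3 carry the same ethyl chain as compound 4 yet differ from compound 1 also on the ring, so no measured step bears directly on this change. A moderate rise in this assay is expected for compound 4, a 3.4-fold higher number from compound 1 to compound 4 (0.53 log units; beyond the scatter), estimated at 5 ug/mL within 1.5 ug/mL to 25 ug/mL.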

Compound 4, half-maximal inhibitory concentration: 1.2 ug/mL
For compound 4 the middle estimate is 4.2-fold (0.62 log units) above the measured one, outside the stated range (below it).
By their numbers in this assay, from the lowest: compounds 4 and 1 (each within the scatter of the next); then compound 3. At a limit, above all of these: compound 2.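

Among these compounds, on the core of compound 1, the first measured step at the chain gives a 1.2-fold lower number from compound 1 to compound 4 (0.09 log units; within the scatter) in this assay, so compounds 1 and 4 cannot be told apart there. At this saturated chain carbon bound to an aromatic carbon, methyl to ethyl therefore leaves the reading within the scatter, something the earlier step, confined to a ring substituent, could not show. From the compounds shown here alone, whether a longer chain such as propyl, or an amine carried on that chain, would read the same stays open. Nothing in the data at hand explains why compounds 1 and 4 read alike.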